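A few compounds are considered here, and "the series" means these few. Any claim that something is new, unique, unknown or untested is made for them only; others in the source may bear on it.

Measured so far in an in vitro functional assay on HEK293S cells for agonist activity at Glucose-dependent insulinotropic receptor (Homo sapiens), read by HTRF and cAMP accumulation, with a stated time of 45 min; a lower number here means that less compound is needed, a higher number that more compound is needed for the effect:

Compound 1, `C[C@@H]1CN(C(=O)OC(C)(C)C)CCN1c1ncc(OCc2ccc(S(=O)(=O)N(C)C)cc2)cn1`: 79 nM
Compound 2, `C[C@@H]1CN(C(=O)OC(C)(C)C)CCN1c1ncc(OCc2ccc(C#N)cc2)cn1`: 39 nM

Compound 2 holds the lower of the two numbers in this assay. Among the compounds with values here, its only neighbour is compound 1, and the single step between them, a 2.0-fold lower number from compound 1 to compound 2 (0.31 log units; beyond the scatter), is modest yet beyond the scatter. That step is the whole of what is known about the aromatic carbon at which the next change is made.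

Compound 3, `C[C@@H]1CN(C(=O)OC(C)(C)C)CCN1c1ncc(OCc2ccc(-n3cnnn3)cc2)cn1`, differs from compound 2 in one place: 1H-tetrazol-1-yl in place of cyano on an aromatic carbon. Within the data shown here, no measured pair tests a tetrazolyl group here; the one step that bears on this position, from the dimethylsulfamoyl group to the cyano group, moved the number only modestly. On that basis the exchange at this carbon is expected to shift the number by no more than a modest amount, with the direction uncertain, and a slightly higher number is taken as the more likely outcome, the expected step being a 1.7-fold higher number from compound 2 to compound 3 (0.22 log units; within the scatter). Compound 3 is therefore estimated at 65 nM in this assay, within a range from 22 nM to 190 nM.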

Compound 3, half-maximal effective concentration: 6 nM
Beside the measured number, compound 3's estimate is 11-fold (1.03 log units) above it; measured number below the stated range.
By their numbers in this assay, from the lowest: compound 3; then compound 2; then compound 1.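

Within the data shown here, the aromatic carbon para to a large group turned out to tolerate more than a small shift: in this assay, 1H-tetrazol-1-yl in place of cyano gave a 6.5-fold lower number from compound 2 to compound 3 (0.81 log units; beyond the scatter), a clearly greater change than the only earlier step at this carbon, a 2.0-fold lower number from compound 1 to compound 2 (0.31 log units; beyond the scatter). Measured against the dimethylsulfamoyl group, the same ring gave a 13-fold lower number from compound 1 to compound 3 (1.12 log units; beyond the scatter), so the three groups now form an order at this carbon, with compound 3 needing the least compound, then compound 2, then compound 1, and every step between them lying beyond the scatter. Nothing measured here accounts for this gain, and the counted differences between the cyano and 1H-tetrazol-1-yl groups cannot be linked to it.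

The compounds shown do not reveal whether the gain is specific to the 1H-tetrazol-1-yl group or would also appear with a carboxylic acid or a primary amide on the same carbon. They also leave open whether it would persist if the tert-butyl carbamate of the shared core were replaced by another group, such as an amine.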